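A few compounds are considered here, and "the series" means these few. Any claim that something is new, unique, unknown or untested is made for them only; others in the source may bear on it.

In a functional assay on K562 cells (Homo sapiens) for cytotoxicity, read by fluorescence, with a stated time of 72 h (on this read-out higher numbers stand for weaker inhibition and lower numbers for stronger inhibition), compound 1 `CSc1nc(NCc2ccc(-c3ccccn3)cc2)c2[nH]nc(C(C)C)c2n1` gives 778 nM and compound 2 `CC(C)c1n[nH]c2c(NCc3ccc(-c4ccccn4)cc3)nc(NCC(N)CO)nc12` gives 700 nM, so compound 2 stands within the scatter of compound 1. Compound 3 `CC(C)c1n[nH]c2c(NCc3ccc(-c4ccccn4)cc3)nc(NCCN(C)C)nc12` carries (dimethylamino)methyl in place of 1-amino-2-hydroxyethyl on a saturated chain carbon bound to a nitrogen on an aromatic ring. Within the data shown here, only one measured step bears on this, and it changes a different place: a 1.1-fold lower number from compound 1 to compound 2 (0.05 log units; within the scatter), which lies within the scatter. No step beyond the scatter is therefore expected, and the estimated step is a 1.1-fold higher number from compound 2 to compound 3 (0.03 log units; within the scatter). The expected value for compound 3 is 750 nM, with an estimated range of 250 nM to 2200 nM.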

Compound 3, half-maximal inhibitory concentration: 125 nM
Beside the measured number, compound 3's estimate is 6.0-fold (0.78 log units) above it, outside the stated range (below it).
By their numbers in this assay, from the lowest: compound 3; then compounds 2 and 1 (each within the scatter of the next).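

In this assay, among these compounds, this position proves responsive: the first change at the aromatic carbon stayed within the scatter, whereas 2-(dimethylamino)ethyl in place of 2-amino-3-hydroxypropyl gives a 5.6-fold lower number from compound 2 to compound 3 (0.75 log units; beyond the scatter) on the same core. Against methylsulfanyl, the (2-(dimethylamino)ethyl)amino group gives a 6.2-fold lower number from compound 1 to compound 3 (0.79 log units; beyond the scatter). No available evidence accounts for this step. The compounds shown do not separate the contribution of the dimethylamino end from that of losing the hydroxy group. On these data alone, whether a longer chain ending in dimethylamino or a pyrrolidine ring would keep this step remains open.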